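Quinolone carboxamide series: cytotoxicity notes on J774.1 cells

The source may hold more compounds than are shown below. What is called first, only, known or untested is meant among the compounds shown, and "the series" means these compounds.

Measured compounds:
compound 1, `CCCn1cc(C(=O)NCc2ccccc2)c(=O)c2cc(F)c(N3CCC(C(N)=O)CC3)cc21`, 43700 nM
compound 2, `CCCn1cc(C(=O)NCc2ccc(OC)cc2)c(=O)c2cc(F)c(N3CCC(C(N)=O)CC3)cc21`, 41400 nM
compound 3, `CCCCn1cc(C(=O)NCc2ccc(OC)cc2)c(=O)c2cc(F)c(N3CCC(C(N)=O)CC3)cc21`, 40800 nM

All three compounds were tested in an ADME assay on J774.1 cells (Mus musculus) for cytotoxicity, read by resazurin assay, with a stated time of 48 h; a higher number here means a weaker inhibitor, a lower number a stronger inhibitor. In this assay compound 1 gives 43700 nM, compound 2 gives 41400 nM and compound 3 gives 40800 nM. The three numbers sit within the scatter of one another, so no order among them can be drawn.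

Two single changes connect the measured compounds. From compound 2 to compound 1 the change is hydrogen in place of methoxy on an aromatic carbon; it made a step of a 1.1-fold higher number from compound 2 to compound 1 (0.02 log units; within the scatter). From compound 2 to compound 3 the change is methyl in place of hydrogen on a saturated chain carbon, three bonds along the chain from an aromatic nitrogen; it made a step of a 1.0-fold lower number from compound 2 to compound 3 (0.01 log units; within the scatter). Neither change moved the number beyond the scatter.

Compound 4, `CCCCn1cc(C(=O)NCc2ccccc2)c(=O)c2cc(F)c(N3CCC(C(N)=O)CC3)cc21`, has not yet been measured. It differs from compound 3 by hydrogen in place of methoxy on an aromatic carbon. This is the same change already seen from compound 2 to compound 1, on the same place of the ring; the two cores carrying it differ by methyl in place of hydrogen on a saturated chain carbon, three bonds along the chain from an aromatic nitrogen. Since that earlier change left the number essentially unchanged, with a 1.1-fold higher number from compound 2 to compound 1 (0.02 log units; within the scatter), a step of about the same size is expected here, estimated at a 1.1-fold higher number from compound 3 to compound 4 (0.02 log units; within the scatter). Compound 4 is therefore expected to give about 43000 nM in this assay, estimated to lie between 28000 nM and 65000 nM. This rests on one pair only, compound 2 and compound 1, so it is a weak expectation.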

Compound 4, half-maximal inhibitory concentration in the J774.1 assay: 47000 nM
Compound 4: middle estimate off by 1.1-fold (0.04 log units), on the low side; low and high end bracket the measured number.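

In the J774.1 assay compound 4 gives 47000 nM. In the J774.1 assay, hydrogen in place of methoxy gives a 1.2-fold higher number from compound 3 to compound 4 (0.06 log units; within the scatter), and this agrees with the earlier step on the other core: the same change on two cores in the J774.1 assay, a 1.1-fold higher number (0.02 log units; within the scatter) from compound 2 to compound 1 and a 1.2-fold higher number (0.06 log units; within the scatter) from compound 3 to compound 4, 1.1-fold (0.04 log units) apart, within the scatter of two such steps. The methyl on the chain gives a 1.1-fold higher number from compound 1 to compound 4 (0.03 log units; within the scatter), and this agrees in the same way: the same change on two cores in the J774.1 assay, a 1.0-fold lower number (0.01 log units; within the scatter) from compound 2 to compound 3 and a 1.1-fold higher number (0.03 log units; within the scatter) from compound 1 to compound 4, 1.1-fold (0.04 log units) apart, within the scatter of two such steps. Both changes therefore carry between these two cores with no step beyond the scatter, but steps this small do not show whether a larger effect would carry over in the same way, and the result covers these four compounds only.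

Still open, going by these compounds, is whether another group in place of methoxy, such as an amine or a carboxylic acid, or a longer chain on the aromatic nitrogen, would move the number beyond the scatter in the J774.1 assay. In a physicochemical assay for lipophilicity, read by HPLC (on this read-out higher numbers stand for higher lipophilicity and lower numbers for lower lipophilicity), compound 3 gives 2.4 and compound 4 gives 2.4. On these data alone, in the physicochemical assay, hydrogen in place of methoxy gives no change at the digits printed from compound 3 to compound 4 (within the scatter), but that reading rests on a single pair, and how the change behaves there on another core remains open.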